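Methyl in place of ring hydrogen on the stilbene acid core

The source may hold more compounds than are shown below. What is called first, only, known or untested is meant among the compounds shown, and "the series" means these compounds.

Three compounds of the series have numbers in an ADME assay on HepG2 cells (Homo sapiens) for cytotoxicity, read by resazurin assay, with a stated time of 24 h; a lower number here means that less compound is tolerated, a higher number that more compound is tolerated. Compound 1 `O=C(O)c1c(O)cc(Cl)cc1C=Cc1ccc2ccccc2c1` gives 25000 nM. Compound 2 `O=C(O)c1c(O)cccc1C=Cc1ccc2ccccc2c1` gives 71000 nM, the highest of the three numbers. Compound 3 `CCN(CC)C(=O)c1c(CCc2ccc3ccccc3c2)cc(OC)cc1OC` gives 59000 nM, which sits within the scatter of compound 2. Among the compounds with values here, the only single-point step among them is a 2.8-fold higher number from compound 1 to compound 2 (0.45 log units; beyond the scatter); compound 1 and compound 3 differ in several places and show no single step.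

Compound 4 `Cc1cc(O)c(C(=O)O)c(C=Cc2ccc3ccccc3c2)c1` is not yet measured in this assay. Against compound 2 the change is methyl in place of hydrogen on an aromatic carbon. Within the data shown here, the one measured step that bears on it is the exchange of a substituent for hydrogen on an aromatic carbon of the same core, where a chloro group went with a lower number than hydrogen. Among the measured compounds shown here, a methyl group is a different substituent, and no measured pair shows what a methyl group does on this core, so the step from compound 1 to compound 2 is only a loose guide. A modest lowering from compound 2 is therefore expected, around the edge of the scatter, rather than none or a large one. Compound 4 is expected to give 40000 nM, with a range from 18000 nM to 80000 nM. That estimate means an expected 1.8-fold lower number from compound 2 to compound 4 (0.25 log units; within the scatter).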

Compound 4, half-maximal cytotoxic concentration: 30000 nM
Compound 4: the middle estimate sits 1.3-fold (0.12 log units) above what was measured; low and high end bracket the measured number.
By their numbers in this assay, from the lowest: compounds 1, 4, 3 and 2 (each within the scatter of the next, the first and the last beyond it).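

Methyl in place of hydrogen on this aromatic carbon, para to a carboxy group and meta to a hydroxy group, gives a 2.4-fold lower number from compound 2 to compound 4 (0.37 log units; beyond the scatter) in this assay, so this position responds to a substituent other than chloro. Methyl in place of chloro on the same carbon gives a 1.2-fold higher number from compound 1 to compound 4 (0.08 log units; within the scatter), and on these numbers the two substituents cannot be told apart. Both chloro and methyl therefore go with a lower number than hydrogen at this position, which means that the lowering seen earlier is not confined to chloro, although this reading rests on compound 1, compound 2 and compound 4 alone.

No measurement at hand explains why either substituent goes with the lower number. From the compounds shown here alone, it remains open whether a fluoro group, an amine, a methoxy group or a longer chain such as propyl on this carbon would follow chloro and methyl or stay with hydrogen, and whether methyl on another carbon of the same ring would give a step of similar size.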